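Swapping the pyrazole substituent on a shared amide core

The source may hold more compounds than are shown below. What is called first, only, known or untested is meant among the compounds shown, and "the series" means these compounds.

Measured compounds:
- Compound 1, `CNC(=O)N1CCCc2ccc(NC(=O)c3cccc(-c4ccccc4)c3)cc21`: 1.39%
- Compound 2, `CNC(=O)N1CCCc2ccc(NC(=O)c3cccc(-c4cn[nH]c4)c3)cc21`: 77.7%
- Compound 3, `CNC(=O)N1CCCc2ccc(NC(=O)c3cccc(-c4cnn(S(C)(=O)=O)c4)c3)cc21`: 18%

All three share the same core and differ only in the group attached to the outer aromatic ring. In a functional assay on MV4-11 cells (Homo sapiens) for antiproliferative activity, with a stated time of 6 days, tested at 6.25 uM (a lower number here means a weaker effect, a higher number a stronger effect of the compound at the concentration tested), compound 3 stands second of the three: above compound 1 by a number 16.6 percentage points higher from compound 1 to compound 3 (beyond the scatter), but well below compound 2, with the step of a number 59.7 percentage points lower from compound 2 to compound 3 (beyond the scatter).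

Compound 4 is `CNC(=O)N1CCCc2ccc(NC(=O)c3cccc(-c4ccn(C(C)=O)n4)c3)cc21`. It differs from compound 3 in one place:
1-acetyl-1H-pyrazol-3-yl in place of 1-(methylsulfonyl)-1H-pyrazol-4-yl on an aromatic carbon

Among the compounds with values here, two measured steps bear on this. The step of a number 76.3 percentage points higher from compound 1 to compound 2 (beyond the scatter) shows how much a pyrazole carrying a free hydrogen on its nitrogen adds, and the step of a number 59.7 percentage points lower from compound 2 to compound 3 (beyond the scatter) shows how much of that gain is lost once the nitrogen carries a substituent. Compound 4 again carries a substituent on the ring nitrogen, so the nearest measured analogue is compound 3 rather than compound 2. A small change in this assay is therefore expected, in either direction, with a wide range.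

For compound 4 the expected value in this assay is 25%, with a range from 5% to 60%. This estimate means an expected step of a number 7 percentage points higher from compound 3 to compound 4 (within the scatter).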

Compound 4, a percentage reported as inhibition, at one concentration (the size of the read-out at that concentration, not a potency): 87.6%
For compound 4 the middle estimate is 62.6 percentage points below the measured one; measured number above the stated range.
By their numbers in this assay, from the lowest: compound 1; then compound 3; then compounds 2 and 4 (each within the scatter of the next).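

Compound 4 shows that a substituent on a pyrazole nitrogen does not by itself remove the effect in this assay: replacing the 1-(methylsulfonyl)-1H-pyrazol-4-yl group with 1-acetyl-1H-pyrazol-3-yl gives a number 69.6 percentage points higher from compound 3 to compound 4 (beyond the scatter), and the comparison with the phenyl group gives a number 86.2 percentage points higher from compound 1 to compound 4 (beyond the scatter). Against the unsubstituted pyrazole, the step is a number 9.9 percentage points higher from compound 2 to compound 4 (within the scatter), so among these compounds a hydrogen on the ring nitrogen is not needed for a high read-out, and the loss seen with compound 3 does not apply to every nitrogen substituent. No measurement here explains why these two substituted pyrazoles differ so much.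

The change from compound 3 to compound 4 alters both the group on the nitrogen and the point at which the pyrazole is attached, so the shown compounds cannot say which of these matters; a 1-acetyl-1H-pyrazol-4-yl group would help separate them. Also open, on these data alone, is whether a longer acyl chain such as propanoyl, or a simple methyl on that nitrogen, would behave like acetyl, and how potency compares, since each read-out comes from one concentration.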